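This account rests on a few compounds, and the source may have more. Where it says the series, first, only, none or still open, it means among the compounds named here.

Of the compounds shown here, two have been measured in a functional assay on MT4 cells (Homo sapiens) for cytotoxicity, read by CellTiter-Glo, with a stated time of 5 days; on this read-out lower numbers stand for an effect already at smaller amounts and higher numbers for an effect only at larger amounts of compound. Compound 1 `Cc1ccc(-c2c(C)noc2CO)cc1S(=O)(=O)NC1CCCC1` gives 6820 nM, while compound 2 `Cc1noc(C)c1-c1cc(-c2c(C)noc2C)c2nc(C3CC3)[nH]c2c1` gives 80 nM. This is the lower of the two numbers, and the gap between them lies beyond the usual scatter. The unmeasured compound 3 `Cc1noc(C)c1-c1cc(S(=O)(=O)NC2CCCC2)c2nc(C3CC3)[nH]c2c1` keeps the core of compound 2 and differs from it in one place, where cyclopentylsulfamoyl takes the place of 3,5-dimethyl-1,2-oxazol-4-yl on an aromatic carbon: cyclopentylsulfamoyl in place of 3,5-dimethyl-1,2-oxazol-4-yl on an aromatic carbon. The remaining 3,5-dimethyl-1,2-oxazol-4-yl group stands meta to the new group. For the measured compounds named here, no measured pair shows this exchange directly, so any expectation rests on indirect evidence. Going by the values given here, compound 1 also carries cyclopentylsulfamoyl, on a different core, and its 6820 nM is the only reading for a compound with that group. In this assay, a move to a higher number, beyond the scatter, is expected for this exchange. The expected change is a 15-fold higher number from compound 2 to compound 3 (1.18 log units; beyond the scatter). For compound 3 the estimated value is 1200 nM, with an expected range from 250 nM to 6000 nM.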

Compound 3, half-maximal effective concentration: 290 nM
Compound 3: the middle estimate sits 4.1-fold (0.62 log units) above what was measured; low and high end bracket the measured number.
By their numbers in this assay, from the lowest: compound 2; then compound 3; then compound 1.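

In this assay, the exchange at this position now has a direct reading: cyclopentylsulfamoyl in place of 3,5-dimethyl-1,2-oxazol-4-yl, on the aromatic carbon ortho to a fused ring, gives a 3.6-fold higher number from compound 2 to compound 3 (0.56 log units; beyond the scatter), a modest step but one beyond the scatter. The number therefore responds to what sits at this place on the shared core, even with the other 3,5-dimethyl-1,2-oxazol-4-yl group and the rest of the core unchanged. Nothing shown here explains the size or direction of this step.

This single exchange changes several things at once, swapping an aromatic ring with hetero atoms for a non-aromatic ring of carbon only and adding a hydrogen-bond donor, so the step cannot assign the shift to any one of these differences. As far as these compounds go, it also remains open how an amine, a carboxylic acid or a longer chain at this place would read, and whether the same exchange at the remaining 3,5-dimethyl-1,2-oxazol-4-yl group would move the number in the same direction.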